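Working notes: the step from compound 2 to compound 4

This account rests on a few compounds, and the source may have more. Where it says the series, first, only, none or still open, it means among the compounds named here.

In an ADME assay on Hepa-1c1c7 cells (Mus musculus) for inhibition (on this read-out higher numbers stand for weaker inhibition and lower numbers for stronger inhibition), compound 2 `C=C(C)[C@@H](O)Cc1c(OC)cc(OC)c2c1O[C@H](c1ccccc1)CC2=O` gives 19.3 ug/mL as its reading. Compound 1 `CO/C(=C\C(=O)c1c(OC)cc2c(c1OC)C=CC(C)(C)O2)c1ccccc1` gives 9.6 ug/mL and lies within the scatter of compound 2. Compound 3 `COc1cc2c(c(OC)c1C(=O)/C=C(\O)c1ccccc1)C=CC(C)(C)O2` gives 6.5 ug/mL as a lower number than compound 2, a gap beyond the scatter.

Compound 4 `COc1cc(OC)c2c(c1CC=C(C)C)O[C@H](c1ccccc1)CC2=O` is still unmeasured and differs from compound 2 in one place: 2-methylprop-1-en-1-yl in place of 1-hydroxy-2-methylprop-2-en-1-yl on a saturated chain carbon bound to an aromatic carbon. In words, 2-methylprop-1-en-1-yl stands in place of 1-hydroxy-2-methylprop-2-en-1-yl on a saturated chain carbon bound to an aromatic carbon.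

For the measured compounds named here, no measured pair tests this change. Going by the values given here, the one measured step (a 1.5-fold lower number from compound 1 to compound 3 (0.17 log units; within the scatter)) is hydrogen in place of methyl on an oxygen on an unsaturated carbon, which is a different change in a different place. It bears only weakly on this question and gives no direction. With so little to go on, no shift beyond the scatter is expected. The expected step is a 1.2-fold lower number from compound 2 to compound 4 (0.08 log units; within the scatter) and this estimate carries no firm direction. In this assay the estimated value for compound 4 is 16 ug/mL with an expected range from 7 ug/mL to 38 ug/mL as its bounds.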

Compound 4, half-maximal inhibitory concentration: 4.1 ug/mL
Beside the measured number, compound 4's estimate is 3.9-fold (0.59 log units) above it, and the stated range ends above it.
By their numbers in this assay, from the lowest: compounds 4, 3, 1 and 2 (each within the scatter of the next, the first and the last beyond it).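

In this assay, the position on a saturated chain carbon bound to an aromatic carbon proves sensitive to the side chain it carries: 2-methylprop-1-en-1-yl in place of 1-hydroxy-2-methylprop-2-en-1-yl gives a 4.7-fold lower number from compound 2 to compound 4 (0.67 log units; beyond the scatter), and stronger inhibition goes with the group that has no hydrogen-bond donor or acceptor. The earlier step, a 1.5-fold lower number from compound 1 to compound 3 (0.17 log units; within the scatter), stayed within the scatter and concerned a different change in a different place, so this is the first single change in the series shown to move the reading beyond the scatter. The change also removes a defined stereocentre and one heavy atom, and no available measurement explains the step or assigns it to any one of these differences.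

The compounds shown leave open whether the step follows the loss of the hydroxyl or the different placing of the double bond within the chain. Going by these compounds, how an amine, a carboxylic acid or a longer saturated chain would read at this same place also remains open.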